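This account rests on a few compounds, and the source may have more. Where it says the series, first, only, none or still open, it means among the compounds named here.

Working notes on the series. The shared core is that of compound 1 `Cc1nc(C(=O)Nc2ccc(Cl)c(-c3nnc4c(Cl)cccn34)c2)cs1`, which in a functional assay on U-251 cells (Homo sapiens) for antiproliferative activity, read by MTT assay, with a stated time of 72 h (on this read-out lower numbers stand for stronger inhibition and higher numbers for weaker inhibition), gives 74300 nM. Compound 2 `O=C(Nc1ccc(Cl)c(-c2nnc3c(Cl)cccn23)c1)c1cccnc1` carries pyridin-3-yl on the carbonyl carbon; in this assay compound 2 returns > 100000 nM, a limit of the assay and not a number. Compound 3 `Cc1cc(Cl)ccc1C(=O)Nc1ccc(Cl)c(-c2nnc3c(Cl)cccn23)c1` carries 4-chloro-2-methylphenyl at the same place; in this assay compound 3 returns > 100000 nM, again a limit rather than a number. Compound 3 therefore stands at the floor of what the assay reports, (the limit of > 100000 nM in this assay, at which 2 of the 3 values shown sit).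

Compound 4 `CS(=O)(=O)c1cccc(C(=O)Nc2ccc(Cl)c(-c3nnc4c(Cl)cccn34)c2)c1` has not been measured. It differs from compound 3 by 3-(methylsulfonyl)phenyl in place of 4-chloro-2-methylphenyl on a carbonyl carbon. The measured steps at this position are an at least 1.3-fold higher number from compound 1 to compound 2 (0.12 log units; that floor lies within the scatter) and an at least 1.3-fold higher number from compound 1 to compound 3 (0.12 log units; that floor lies within the scatter), both floors that lie within the scatter, while a step that the two limits leave unreadable from compound 2 to compound 3. Among the measured compounds shown here, none of these is the change to compound 4, and none reads a change beyond the scatter; every variation so far on the carbonyl carbon lands at or close to the limit. No step beyond the scatter is therefore expected in this assay. The estimate implies a number no higher from compound 3 to compound 4 (the limit leaves the size open), which is no expected change beyond the scatter. For compound 4 in this assay the estimate is 100000 nM, with a range from 30000 nM to 300000 nM, and a limit-only result is expected to be quite possible.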

Compound 4, half-maximal inhibitory concentration: > 100000 nM
Compound 4 gave a limit, no number; the forecaster's own chance of this, stated with the estimate: 65%; the middle value lies on the limit itself.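

In this assay compound 4 gives > 100000 nM, a limit of the assay and not a number, so 3-(methylsulfonyl)phenyl, with 2 hydrogen-bond acceptors where 4-chloro-2-methylphenyl has 0, leaves the series at that limit. Among the compounds shown here, the only readable comparison for this group is with the one compound that returns a number, and it shows an at least 1.3-fold higher number from compound 1 to compound 4 (0.12 log units; that floor lies within the scatter); the steps to compound 4 from compound 2 and compound 3 cannot be read. With a third group on the carbonyl carbon now sitting at the same limit, the position shows no change beyond the scatter for any group shown, and the limit has become the usual result here: the limit of > 100000 nM in this assay, at which 3 of the 4 values shown sit.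

The compounds shown do not tell whether compound 2, compound 3 and compound 4 differ from one another, or whether 2-methyl-1,3-thiazol-4-yl truly stands apart from the three groups at the limit. Also open, as far as these compounds go, is whether an amine, a carboxylic acid or a longer chain on the carbonyl carbon would return a number clearly separated from that limit.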